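Chloro to Fluoro on the Benzylsulfanyl Arm

A few compounds are considered here, and "the series" means these few. Any claim that something is new, unique, unknown or untested is made for them only; others in the source may bear on it.

Of the compounds shown here, three built on a shared core have been tested in a functional assay on the whole organism (artery, strain albino) with Rattus norvegicus as the target, with a stated time of 600 min, at a dose of 10 mg/kg by the oral route; on this read-out lower numbers stand for less inhibition and higher numbers for more inhibition at the one dose given (going by the name of the read-out). Compound 1, `COc1ccc(C2N=C(SCc3ccc(Cl)cc3)NC(C)=C2C(=O)Nc2ccc(F)cc2)cc1OC`, gives 26.7% in this assay. Compound 2, `COc1ccc(C2N=C(SCc3ccc(F)cc3)NC(C)=C2C(=O)Nc2ccc(F)cc2)cc1OC`, differs from compound 1 in one place: fluoro in place of chloro on an aromatic carbon. In this assay compound 2 gives 21%. The step of a number 5.7 percentage points lower from compound 1 to compound 2 (within the scatter) shows that the two readings lie within the usual scatter of one another, so no real change can be read from this swap in this pair.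

Compound 3, `CC1=C(C(=O)Nc2ccc([N+](=O)[O-])cc2)C(c2ccc(Br)cc2)N=C(SCc2ccc(Cl)cc2)N1`, carries a different set of groups on the shared core; the difference between its core and that of compound 1 is not broken down here. In this assay compound 3 gives 34.4%, a number within the scatter of compound 1 and beyond the scatter of compound 2.

Compound 4, `CC1=C(C(=O)Nc2ccc([N+](=O)[O-])cc2)C(c2ccc(Br)cc2)N=C(SCc2ccc(F)cc2)N1`, has not yet been measured. It differs from compound 3 by the same change that separates compound 2 from compound 1: fluoro in place of chloro on an aromatic carbon. Among the measured compounds shown here, the change sits at the same place in both pairs, on an aromatic carbon of a six-membered aromatic ring of carbon only, para to a large group, so the earlier step is the only guide available. Because a number 5.7 percentage points lower from compound 1 to compound 2 (within the scatter) stayed within the scatter, a step of similar size is expected here, namely a number 5.4 percentage points lower from compound 3 to compound 4 (within the scatter). Compound 4 is therefore estimated to give 29% in this assay, most likely between 16% and 42%.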

Compound 4, a percentage reported as inhibition, in the whole organism at one dose (the size of the read-out at that dose, not a potency): 32.3%
Compound 4: middle estimate off by 3.3 percentage points, on the low side; measured number inside the range.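

In this assay, putting fluoro in place of chloro on the second core gives a number 2.1 percentage points lower from compound 3 to compound 4 (within the scatter), so these two readings cannot be told apart. Set beside the same swap on the first core, the result looks alike on both cores, with no sign that the core changes what the swap does: the same change on two cores in this assay, a number 5.7 percentage points lower (within the scatter) from compound 1 to compound 2 and a number 2.1 percentage points lower (within the scatter) from compound 3 to compound 4, 3.6 percentage points apart, within the scatter of two such steps. Among the compounds shown here, this shows only that the swap left the reading within the usual scatter in both pairs; neither step stands clear of that scatter, so it does not show a real effect of the swap on either core, and two pairs make no rule for other cores.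

The compounds shown carry only chloro or fluoro at this place on the benzyl ring, so it remains open whether a trifluoromethyl group, an amine or a carboxylic acid there would move the reading beyond the scatter. Going by these compounds, it is also open whether a longer chain in place of the benzyl arm would do so, and whether any such change would carry from one core to the other.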